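Methoxy in place of fluoro on the aryl ring

A few compounds are considered here, and "the series" means these few. Any claim that something is new, unique, unknown or untested is made for them only; others in the source may bear on it.

Compound 3 `Fc1ccc(C2CC(c3ccc4c(c3)OCCO4)=NN2c2ccccc2)cc1` gives 6050 nM in a functional assay on WM 266-4 cells (Homo sapiens) for antiproliferative activity, read by MTT assay, with a stated time of 24 h (a higher number here means a weaker inhibitor of growth, a lower number a stronger inhibitor of growth), and holds the higher of the two numbers shown; in this assay compound 2 `c1ccc(COc2cccc(C3CC(c4ccc5c(c4)OCCO5)=NN3c3ccccc3)c2)cc1` gives 870 nM. Compound 1 `FC(F)(F)c1ccc(C2CC(c3ccc4c(c3)OCCO4)=NN2c2ccccc2)cc1` sits only at the limit > 100000 nM of this assay (the limit of > 100000 nM in this assay, at which 1 of the 3 values shown sits). Going by the values given here, the one measured step, an at least 16-fold lower number from compound 1 to compound 3 (1.21 log units; beyond the scatter), shows that the group on this aryl carbon can move the number strongly. Compound 4 `COc1ccc(C2CC(c3ccc4c(c3)OCCO4)=NN2c2ccccc2)cc1` differs from compound 3 by methoxy in place of fluoro on an aromatic carbon. Among the compounds with values here, no measured step exchanges fluoro for methoxy, so the direction is open and only a moderate step is expected, with wide uncertainty. Compound 4 is expected at 3500 nM, between 800 nM and 15000 nM. The expected step is a 1.7-fold lower number from compound 3 to compound 4 (0.24 log units; within the scatter).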

Compound 4, concentration for 50% growth inhibition: > 100000 nM
Compound 4 gave a limit, no number; the forecaster's own chance of this, stated with the estimate: 10%; middle value at least 28-fold (1.45 log units) from the limit.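

Methoxy in place of fluoro on this aromatic carbon, para to a large group, gives an at least 16-fold higher number from compound 3 to compound 4 (1.21 log units; beyond the scatter). The earlier step showed only that trifluoromethyl fares worse than fluoro here; methoxy now shows the same, so of the three groups on this carbon, only fluoro gives a readable number. The step between the two limit compounds, compound 1 and compound 4, cannot be read: the limit of > 100000 nM in this assay, at which 2 of the 4 values shown sit.

On these data alone, whether chloro, an amine or a bare hydrogen on this carbon would give a number remains open. With no readable value for methoxy or trifluoromethyl, these two groups cannot be ranked.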